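A Methyl Group Added to Two Related Aryl Ether Cores

A few compounds are considered here, and "the series" means these few. Any claim that something is new, unique, unknown or untested is made for them only; others in the source may bear on it.

Compound 1 `Cc1cccc(C#CCOc2ccccc2)n1` and compound 2 `Cc1ccc(OCC#Cc2cccc(C)n2)cc1` share a core and differ only by a methyl group. In a functional assay with metabotropic glutamate receptor 5 (Homo sapiens) as the target, read by FLIPR (on this read-out higher numbers stand for weaker inhibition and lower numbers for stronger inhibition), compound 1 gives > 10000 nM, a limit of the assay rather than a number. In this assay compound 2 gives 115 nM. The step between them is an at least 86-fold lower number from compound 1 to compound 2 (1.93 log units; beyond the scatter), the change being (methyl in place of hydrogen on an aromatic carbon). The limit itself is part of the picture here, since (the limit of > 10000 nM in this assay, at which 2 of the 3 values shown sit).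

Compound 3 `Cc1cccc(C#CCOc2cccnc2)n1` carries a different core; how that core differs from the core of compound 1 is not broken down here. In this assay compound 3 gives > 10000 nM, again a limit rather than a number.

Compound 4 `Cc1ccc(OCC#Cc2cccc(C)n2)cn1` has not yet been measured. It stands to compound 3 as compound 2 stands to compound 1, the change being (methyl in place of hydrogen on an aromatic carbon). The two changes are the same kind of change, though not the same: in compound 2 the methyl sits on an aromatic carbon of a six-membered aromatic ring of carbon only, para to a large group, while in compound 4 it sits on a six-membered aromatic ring with 1 nitrogen, next to the ring nitrogen and para to a large group.

Because the measured step of an at least 86-fold lower number from compound 1 to compound 2 (1.93 log units; beyond the scatter) is large, a gain of similar size is expected from compound 3 to compound 4, an at least 16-fold lower number from compound 3 to compound 4 (1.22 log units; beyond the scatter). Compound 4 is therefore estimated to give about 600 nM in this assay, expected to fall between 100 nM and 5000 nM.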

Compound 4, half-maximal inhibitory concentration: 2490 nM
Compound 4: the middle estimate sits 4.2-fold (0.62 log units) below what was measured, and the stated range covers the measured number.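

The same change, methyl in place of hydrogen on an aromatic carbon, also lowers the number on the core of compound 3, with an at least 4.0-fold lower number from compound 3 to compound 4 (0.60 log units; beyond the scatter) in this assay, so across the two pairs shown its direction carries over from one core to the other. Set side by side, however, the two steps cannot be ranked by size: the same change on two cores in this assay, an at least 86-fold lower number (1.93 log units; beyond the scatter) from compound 1 to compound 2 and an at least 4.0-fold lower number (0.60 log units; beyond the scatter) from compound 3 to compound 4; the limit leaves it open whether they differ Both steps start from a limit, so neither gives the full size of the gain, and two pairs do not show that the change would carry over to any further core in the series: the limit of > 10000 nM in this assay, at which 2 of the 4 values shown sit.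

The compounds shown leave open whether another group in the same place, such as ethyl, methoxy, chlorine or trifluoromethyl, would lower the number as methyl does on either core. They also leave open whether a longer chain or an amine there would keep the gain, and whether the methyl would have a similar effect on a ring carrying its nitrogen elsewhere.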